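The source may hold more compounds than are shown below. What is called first, only, known or untested is meant among the compounds shown, and "the series" means these compounds.

Compound 1 `Cc1cc2nc(O)c(O)nc2c([N+](=O)[O-])c1C`: 2.6 mg/kg
Compound 2 `CCc1cc2nc(O)c(O)nc2c([N+](=O)[O-])c1Br`: 11 mg/kg
Compound 3 `CCc1cc2nc(O)c(O)nc2c([N+](=O)[O-])c1Cl`: 4.5 mg/kg

These values come from a functional assay on the whole organism with Mus musculus as the target, in the maximal electroshock model; a lower number here means that less compound is needed, a higher number that more compound is needed for the effect. Compound 1 lies within the scatter of compound 3 and stands beyond the scatter from compound 2, which has the higher number.

Compound 4 `Cc1c(F)cc2nc(O)c(O)nc2c1[N+](=O)[O-]` differs from compound 1 by one change: fluoro in place of methyl on an aromatic carbon. For the measured compounds named here, only one measured step bears on this, and only loosely: a 2.4-fold lower number from compound 2 to compound 3 (0.39 log units; beyond the scatter), a modest exchange of chloro in place of bromo. Going by the values given here, no measured step replaces methyl with fluoro, so the direction remains uncertain, and no step beyond the scatter is expected. The estimated change is a 1.5-fold higher number from compound 1 to compound 4 (0.19 log units; within the scatter). For compound 4 the expected value is 4 mg/kg, with an estimated range of 1.5 mg/kg to 11 mg/kg.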

Compound 4, dose for half-maximal effect: 1.8 mg/kg
Compound 4: middle estimate off by 2.2-fold (0.35 log units), on the high side; the range from low to high includes it.
By their numbers in this assay, from the lowest: compounds 4, 1 and 3 (each within the scatter of the next, the first and the last beyond it); then compound 2.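

At this position, ortho to a methyl group and meta to a nitro group, the earlier compounds carried only methyl or ethyl, so compound 4 is the first shown with a halogen there. In this assay, fluoro in place of methyl gives a 1.4-fold lower number from compound 1 to compound 4 (0.16 log units; within the scatter), so this exchange leaves the effect in the same range. Nothing measured on the compounds explains this outcome.

From the compounds shown here alone, whether chloro, a methoxy group or an amine at this position would also hold the value stays open. So does whether a longer chain would be tolerated here.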